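Methoxy-to-fluoro swap on the pendant aryl, cytotoxicity notes

The source may report more compounds than this note shows. Statements on the series, on what has been measured and on what is new or still open speak of the compounds shown alone.

Compound 1 `COc1ccc(-c2cc(=O)c3cc(NC(C)=O)ccc3o2)cc1` and compound 2 `CC(=O)Nc1ccc2oc(-c3ccc(F)cc3)cc(=O)c2c1` share one core. In an ADME assay on THP-1 cells (Homo sapiens) for cytotoxicity, read by flow cytometry and propidium iodide staining, with a stated time of 72 h (a higher number here means a weaker inhibitor, a lower number a stronger inhibitor), compound 1 gives 74000 nM and compound 2 gives 22000 nM. The change between them, (fluoro in place of methoxy on an aromatic carbon), produced a 3.4-fold lower number from compound 1 to compound 2 (0.53 log units; beyond the scatter). Compound 3 `COc1ccccc1-c1cc(=O)c2cc(N)ccc2o1` carries a different core; the difference between the two cores is not broken down here. In this assay compound 3 gives 74000 nM, level with compound 1 at the digits recorded and within the scatter of it. Compound 4 `Nc1ccc2oc(-c3ccccc3F)cc(=O)c2c1` awaits measurement in this assay. It differs from compound 3 by fluoro in place of methoxy on an aromatic carbon, the same kind of change as between compound 1 and compound 2, though the surroundings differ: there the place was para to a large group, here it is ortho to a large group. Because a 3.4-fold lower number from compound 1 to compound 2 (0.53 log units; beyond the scatter) was modest and the place is not identical, the expected step is a 2.5-fold lower number from compound 3 to compound 4 (0.39 log units; beyond the scatter), somewhat tempered. Compound 4 is expected at 30000 nM, most likely between 12000 nM and 80000 nM.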

Compound 4, half-maximal inhibitory concentration: 44000 nM
For compound 4 the middle estimate is 1.5-fold (0.17 log units) below the measured one; measured number inside the range.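

Fluoro in place of methoxy on an aromatic carbon, here ortho to a large group, gives a 1.7-fold lower number from compound 3 to compound 4 (0.23 log units; within the scatter) in this assay. Set beside the earlier pair, the step shows no difference between the two cores that stands clear of the scatter: the same change on two cores in this assay, a 3.4-fold lower number (0.53 log units; beyond the scatter) from compound 1 to compound 2 and a 1.7-fold lower number (0.23 log units; within the scatter) from compound 3 to compound 4, 2.0-fold (0.30 log units) apart, within the scatter of two such steps This is compatible with the change carrying over from one core to the other, but two pairs do not establish a constant step, and they differ in both core and place, so neither influence can be separated from the other.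

The compounds shown leave open how chloro or nitrile would read in place of methoxy in this assay. Also open, from the compounds shown here alone, is whether the step would hold on a core bearing a carboxylic acid.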